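A Dimethylamino Chain Replaces a Fluorobenzyl Group

A few compounds are considered here, and "the series" means these few. Any claim that something is new, unique, unknown or untested is made for them only; others in the source may bear on it.

The series shares one core, carried by compound 1 `O=C(NCc1ccc(F)cc1)c1nc(Br)c2cccnc2c1NCc1ccccc1`, compound 2 `NCCCCCCNc1c(C(=O)NCc2ccc(F)cc2)nc(Br)c2cccnc12` and compound 3 `O=C(NCc1ccc(F)cc1)c1nc(Br)c2cccnc2c1NCc1ccc(F)cc1`; they differ only in the group attached to the nitrogen on the aromatic ring. In a functional assay on MCF7 cells (Homo sapiens) for cytotoxicity, read by MTT assay, with a stated time of 72 h (on this read-out lower numbers stand for stronger inhibition and higher numbers for weaker inhibition), compound 2 gives 2000 nM. In this assay, among the measured compounds shown here, compound 1 gives "not determined" (no result reported), and in this assay compound 3 gives "not determined" (no result reported), so compound 2 holds the only measured value in the set.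

Compound 4 `CN(C)CCCNc1c(C(=O)NCc2ccc(F)cc2)nc(Br)c2cccnc12` is the next member. Against compound 3 the change is 2-(dimethylamino)ethyl in place of 4-fluorophenyl on a saturated chain carbon bound to a nitrogen on an aromatic ring. Since compound 3 has no number, the size and direction of the step from compound 3 to compound 4 in this assay cannot be set from the data; what remains is the comparison with compound 2, which also carries a nitrogen-bearing saturated chain on that ring nitrogen and gives 2000 nM.

On that basis compound 4 is expected to land near compound 2, at an estimated 2000 nM, with a plausible range from 500 nM to 8000 nM in this assay. This is an estimate resting on a single measured neighbour, and it should be read with that caution.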

Compound 4, half-maximal inhibitory concentration: 7000 nM
Compound 4: the middle estimate sits 3.5-fold (0.54 log units) below what was measured; measured number inside the range.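

In this assay there are now two measured chains on the shared core, and they can be compared directly (a 3.5-fold higher number from compound 2 to compound 4 (0.54 log units; beyond the scatter)), a modest step that is nevertheless beyond the usual scatter. Among the compounds shown here, it is the first sign that this position responds to what the saturated chain carries: dimethylamino in place of 3-aminopropyl, three bonds along the chain from a nitrogen on an aromatic ring, gives a higher number and so weaker inhibition. The steps involving compound 1 and compound 3 cannot be read, as neither has a number, and no measurement here bears on the reason for the shift.

The pair leaves open whether the rise follows the dimethylamino end group or the chain that carries it, a question that a free primary amine or a dimethylamino group on a longer chain would help to settle. It also leaves open how a morpholine or a carboxylic acid at the chain end would read, and where a benzyl group on this nitrogen would fall relative to either chain.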